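Aryl swap on the shared core, compound 2 to compound 4

The source may hold more compounds than are shown below. What is called first, only, known or untested is meant among the compounds shown, and "the series" means these compounds.

The three measured compounds share one core and differ only in the aryl group on it. Compound 1 `Cc1nc2c3ccccc3ccc2c2nc3c(ccc4ccccc43)c(-c3nccnc3N)c12` gives 2260 nM in a functional assay on AGS cells (Homo sapiens) for cytotoxicity, read by MTT assay, with a stated time of 48 h; a higher number here means a weaker inhibitor, a lower number a stronger inhibitor. Compound 2 `Cc1nc2c3ccccc3ccc2c2nc3c(ccc4ccccc43)c(-c3cccc4ccccc34)c12` gives 12100 nM in this assay, and compound 3 `Cc1nc2c3ccccc3ccc2c2nc3c(ccc4ccccc43)c(-c3ccc(O)cc3)c12` gives 14200 nM. Compound 2 stands well apart from compound 1, as a 5.4-fold higher number from compound 1 to compound 2 (0.73 log units; beyond the scatter), and compound 3 likewise, as a 6.3-fold higher number from compound 1 to compound 3 (0.80 log units; beyond the scatter); between the other two, a 1.2-fold higher number from compound 2 to compound 3 (0.07 log units; within the scatter) lies within the scatter, so compound 2 and compound 3 share one band. Compound 4 `Cc1ccc(-c2c3ccc4ccccc4c3nc3c2c(C)nc2c4ccccc4ccc32)cc1` is not yet measured. It differs from compound 2 in one place: 4-methylphenyl in place of naphthalen-1-yl on an aromatic carbon. The step that bears on this is the exchange of the same naphthalen-1-yl for 4-hydroxyphenyl, a 1.2-fold higher number from compound 2 to compound 3 (0.07 log units; within the scatter), which brought no change beyond the scatter; the two larger steps concern the 3-aminopyrazin-2-yl of compound 1 leaving and do not apply. A step of a 1.1-fold higher number from compound 2 to compound 4 (0.03 log units; within the scatter) is therefore expected, that is none beyond the scatter. Compound 4 is estimated at 13000 nM, with a range of 5000 nM to 35000 nM.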

Compound 4, half-maximal inhibitory concentration: > 80000 nM
Compound 4 gave a limit, no number; the forecaster's own chance of this, stated with the estimate: 10%; middle value at least 6.1-fold (0.78 log units) from the limit.
By their numbers in this assay, from the lowest: compound 1; then compounds 2 and 3 (each within the scatter of the next). At a limit, above all of these: compound 4.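

In this assay compound 4 gives > 80000 nM, which is a limit of the assay and not a number. For the compounds shown here, the aryl groups at this position are therefore not interchangeable, as the earlier compounds might have suggested: 4-methylphenyl in place of naphthalen-1-yl gives an at least 6.6-fold higher number from compound 2 to compound 4 (0.82 log units; beyond the scatter), and methyl in place of hydroxy on the single aromatic ring gives an at least 5.6-fold higher number from compound 3 to compound 4 (0.75 log units; beyond the scatter), so one small group on that ring separates two compounds. The distance from the 3-aminopyrazin-2-yl compound also widens, at an at least 35-fold higher number from compound 1 to compound 4 (1.54 log units; beyond the scatter), and the ring count of the aryl group does not sort the series, since compound 3 and compound 4 each carry one ring and compound 2 carries two.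

Going by these compounds, the true value of compound 4 stays open beyond its limit. Also open, on these data alone, is whether an amine, a methoxy or a carboxylic acid in place of the hydroxy would stay with compound 3 or go with compound 4.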